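A few compounds are considered here, and "the series" means these few. Any claim that something is new, unique, unknown or untested is made for them only; others in the source may bear on it.

In a functional assay on K562 cells (Homo sapiens) for antiproliferative activity, with a stated time of 72 h (a higher number here means a weaker inhibitor, a lower number a stronger inhibitor), compound 1 `Nc1ncnn2c([C@@H]3O[C@H](CO)[C@@H](O)[C@H]3O)cc(C#Cc3ccccc3)c12` gives only a limit, > 100000 nM. Compound 2 `Cc1ccccc1-c1cc([C@@H]2O[C@H](CO)[C@@H](O)[C@H]2O)n2ncnc(N)c12` also gives only a limit, > 100000 nM. Both sit at the same edge of the scale, (the limit of > 100000 nM in this assay, at which 2 of the 2 values shown sit). Within the data shown here, the one measured step is a step that the two limits leave unreadable from compound 1 to compound 2, so it offers no size to carry forward. Compound 3 `Nc1ncnn2c([C@@H]3O[C@H](CO)[C@@H](O)[C@H]3O)cc(/C=C/c3ccccc3)c12` has 2-phenylethenyl in place of 2-methylphenyl on an aromatic carbon. With no readable step as a guide, no change beyond the scatter is expected, and the expected step is a number no higher from compound 2 to compound 3 (the limit leaves the size open). Compound 3 is estimated at 100000 nM, with an expected range of 30000 nM to 300000 nM.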

Compound 3, half-maximal inhibitory concentration: 3100 nM
Beside the measured number, compound 3's estimate is 32-fold (1.51 log units) above it; measured number below the stated range.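

In this assay, this aromatic carbon gives its first readable change: 2-phenylethenyl in place of 2-methylphenyl brings an at least 32-fold lower number from compound 2 to compound 3 (1.50 log units; beyond the scatter), and 2-phenylethenyl in place of 2-phenylethynyl brings an at least 32-fold lower number from compound 1 to compound 3 (1.50 log units; beyond the scatter). The group at this place can therefore move the read-out, and replacing the 2-phenylethynyl group with a 2-phenylethenyl group is enough to do so. Both sizes are measured against limits, not numbers: the limit of > 100000 nM in this assay, at which 2 of the 3 values shown sit.

The compounds shown leave open whether the double bond or the phenyl ring matters more to this change. From the compounds shown here alone, how a saturated 2-phenylethyl chain or an amine at this place would read also remains open.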